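The source may report more compounds than this note shows. Statements on the series, on what has been measured and on what is new or still open speak of the compounds shown alone.

Working notes on the series

Compound 1 `CCCOC(=O)C1=C(C)NC(=S)NC1c1ccco1` and compound 2 `CC1=C(C(=O)OCC(C)C)C(c2ccco2)NC(=S)N1` share one core; compound 3 `CCOC(=O)C1=C(C)N(C)C(=O)NC1c1ccsc1` and compound 4 `CCCOC(=O)C1=C(C)N(C)C(=O)NC1c1ccsc1` share another. How the core of compound 3 differs from the core of compound 1 is not broken down here. In an assay on membranes from HEK293 cells for displacement of a labelled ligand from adenosine receptor A2b (Homo sapiens), read by scintillation counting, with a stated time of 30 min, tested at 1 uM (a higher number here means more inhibition at the concentration tested (going by the name of the read-out), a lower number less inhibition), compound 1 gives 46%, compound 2 gives 18%, and compound 3 gives 53%. The step of a number 28 percentage points lower from compound 1 to compound 2 (beyond the scatter) follows the change (methyl in place of hydrogen on a saturated chain carbon bound to two saturated chain carbons).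

Compound 4 carries the same kind of change relative to compound 3, (methyl in place of hydrogen on a saturated chain carbon, two bonds along the chain from an oxygen next to a carbonyl group), though the place differs: in the first pair the carbon is bound to two saturated chain carbons, in the second it lies two bonds along the chain from an oxygen next to a carbonyl group. The earlier step went down beyond the scatter, and compound 3 stands nearest to compound 1, within the scatter. A smaller downward step is therefore expected, a number 11 percentage points lower from compound 3 to compound 4 (beyond the scatter), because compound 1 to compound 2 gave a number 28 percentage points lower from compound 1 to compound 2 (beyond the scatter) on a different place of the chain. In this assay compound 4 is estimated at 42%, expected between 22% and 60%.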

Compound 4, a percentage reported as inhibition, at one concentration (the size of the read-out at that concentration, not a potency): 1%
Estimate against measurement, compound 4: 41 percentage points above, and the stated range ends above it.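

In this assay the new step, a number 52 percentage points lower from compound 3 to compound 4 (beyond the scatter), points the same way as the earlier one, but its size does not carry over from one core to the other: the same change on two cores in this assay, a number 28 percentage points lower (beyond the scatter) from compound 1 to compound 2 and a number 52 percentage points lower (beyond the scatter) from compound 3 to compound 4, 24 percentage points apart, beyond the scatter of two such steps

The direction therefore holds in both pairs shown, while the size read on one pair is no guide to the size on the other. The added methyl also sits at a different place on the chain in each pair, so the data do not tell core and place apart as the source of the gap, and two pairs give no rule for the series.

What the compounds shown leave open is whether a longer chain, such as butoxy, or a chain ending in an amine or a carboxylic acid would follow the same downward direction on either core. Also open, from the compounds shown here alone, is whether a methyl at the same chain carbon on both cores would give steps of similar size.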